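This account rests on a few compounds, and the source may have more. Where it says the series, first, only, none or still open, it means among the compounds named here.

Measured in a functional assay on Bel-7402 cells (Homo sapiens) for cytotoxicity, read by MTT assay, with a stated time of 72 h; on this read-out lower numbers stand for stronger inhibition and higher numbers for weaker inhibition:
- compound 1 `CC(=C\c1ccccc1)/C=C1\CCC=CC1=O`: 3900 nM
- compound 2 `Cc1ccc(/C=C/C=C2\CCC=CC2=O)cc1`: 6300 nM

Among the measured compounds shown here, only two numbers are available so far. Compound 2 gives 6300 nM and lies within the usual scatter of compound 1 at 3900 nM, so the two cannot be told apart on this read-out. Compound 2 therefore serves as the reference point for the next comparison, without any ranking in the pair.

The next compound is compound 3 `O=C1C=CCC/C1=C\C=C\c1ccc(Br)cc1`, which differs from compound 2 by one exchange: bromo in place of methyl on an aromatic carbon. This places bromo in place of methyl on an aromatic carbon, para to a large group.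

For the measured compounds named here, no two measured compounds differ in only one place, so the series gives no direct measure of this exchange. Any expectation rests on the narrow span from compound 1 at 3900 nM to compound 2 at 6300 nM. In this assay, no change beyond the scatter is expected, with a slight lean towards a lower number. The expected step is a 1.4-fold lower number from compound 2 to compound 3 (0.15 log units; within the scatter). For compound 3 the estimated value is 4500 nM, with an expected range of 1700 nM to 11000 nM.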

Compound 3, half-maximal inhibitory concentration: 3600 nM
Compound 3: middle estimate off by 1.3-fold (0.10 log units), on the high side; measured number inside the range.
By their numbers in this assay, from the lowest: compounds 3, 1 and 2 (each within the scatter of the next).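

In this assay, among the compounds shown here, the exchange of methyl for bromo on this aromatic carbon, para to a large group, gives a 1.8-fold lower number from compound 2 to compound 3 (0.24 log units; within the scatter) and is the first direct measure of a single change. Before this step, the only comparison set compound 1 against compound 2, which differ in more than one place and so gave no reading for this position. The new step shows that the read-out does not separate bromo from methyl at this carbon, and no supporting measurement is available to interpret that result.

Still open, from the compounds shown here alone, is whether an amine, a carboxylic acid or a longer chain on this same aromatic carbon would give a step beyond the scatter, since one exchange between two single-atom groups says little about the position as a whole. Also open, going by these compounds, is whether bromo would read the same on another carbon of the aromatic ring, and whether this exchange would read the same on the core of compound 1.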